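Shortening a side chain on a methylated core

This account rests on a few compounds, and the source may have more. Where it says the series, first, only, none or still open, it means among the compounds named here.

Compound 1 `CN(C)CCCN1CCN(CC(=O)Nc2ccc(-c3nc4cc(F)ccc4o3)cc2)CC1` gives 14800 nM in a functional assay on MCF7 cells (Homo sapiens) for cytotoxicity, read by MTT assay, with a stated time of 24 h; a lower number here means a stronger inhibitor, a higher number a weaker inhibitor. Compound 2 `CN(C)CCN1CCN(CC(=O)Nc2ccc(-c3nc4cc(F)ccc4o3)cc2)CC1` differs from it by dimethylamino in place of (dimethylamino)methyl on a saturated chain carbon, two bonds along the chain from an amine nitrogen in a ring and gives 20800 nM; the step of a 1.4-fold higher number from compound 1 to compound 2 (0.15 log units; within the scatter) is small. Compound 3 `Cc1cc(-c2nc3cc(F)ccc3o2)ccc1NC(=O)CN1CCN(CCCN(C)C)CC1` carries a different core, differing from compound 1 by methyl in place of hydrogen on an aromatic carbon. In this assay compound 3 gives 7770 nM, a step of a 1.9-fold lower number from compound 1 to compound 3 (0.28 log units; within the scatter). Compound 4 `Cc1cc(-c2nc3cc(F)ccc3o2)ccc1NC(=O)CN1CCN(CCN(C)C)CC1` has not yet been measured. It differs from compound 3 by dimethylamino in place of (dimethylamino)methyl on a saturated chain carbon, two bonds along the chain from an amine nitrogen in a ring, the same change, at the same place, that separates compound 1 from compound 2, here on the core of compound 3. Because that earlier step was a 1.4-fold higher number from compound 1 to compound 2 (0.15 log units; within the scatter), a similar step of about a 1.4-fold higher number from compound 3 to compound 4 (0.15 log units; within the scatter) is expected for compound 4. Compound 4 is therefore estimated at 10900 nM, likely between 5000 nM and 25000 nM.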

Compound 4, half-maximal inhibitory concentration: 10400 nM
Beside the measured number, compound 4's estimate is 1.0-fold (0.02 log units) above it; the measured number falls inside the stated range.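

Swapping 3-(dimethylamino)propyl for 2-(dimethylamino)ethyl gives much the same result on both cores in this assay, with a 1.3-fold higher number from compound 3 to compound 4 (0.13 log units; within the scatter) matching the earlier step: the same change on two cores in this assay, a 1.4-fold higher number (0.15 log units; within the scatter) from compound 1 to compound 2 and a 1.3-fold higher number (0.13 log units; within the scatter) from compound 3 to compound 4, 1.1-fold (0.02 log units) apart, within the scatter of two such steps. Methyl in place of hydrogen on an aromatic carbon also reads alike on both chains, with a 2.0-fold lower number from compound 2 to compound 4 (0.30 log units; within the scatter): the same change on two cores in this assay, a 1.9-fold lower number (0.28 log units; within the scatter) from compound 1 to compound 3 and a 2.0-fold lower number (0.30 log units; within the scatter) from compound 2 to compound 4, 1.1-fold (0.02 log units) apart, within the scatter of two such steps. Among the compounds shown here, all these steps lie within the scatter, so the four compounds show only that the two changes combine without surprise, not that either change has a real effect or that this agreement would hold on any other core.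

On these data alone, whether a longer chain or a diethylamino group in place of dimethylamino would follow the same pattern remains open. So does the result of chlorine in place of that methyl.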